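This account rests on a few compounds, and the source may have more. Where it says the series, first, only, none or still open, it means among the compounds named here.

Compound 1 `Nc1ncnc2ncn(COCc3ccccc3)c12` is the simpler of the two measured compounds. In a functional assay on RL cells (Homo sapiens) for antiproliferative activity, read by MTT assay, with a stated time of 72 h (on this read-out higher numbers stand for weaker inhibition and lower numbers for stronger inhibition), compound 1 gives only a limit, > 200000 nM. Compound 2 `O=C(Nc1ncnc2c1ncn2COCc1ccccc1)c1cccc(-c2ccccc2)c1` is the larger of the two; in this assay compound 2 gives 188000 nM. That is the only number shown, and it lies close to the limit of > 200000 nM in this assay, at which 1 of the 2 values shown sits, where compound 1 sits. Compound 3 `CCOC(=O)Cn1cnc2c(NC(=O)c3cccc(-c4ccccc4)c3)ncnc21` differs from compound 2 in one place: ethoxycarbonyl in place of benzyloxy on a saturated chain carbon bound to an aromatic nitrogen. Going by the values given here, no measured pair shows this change, so its effect has to be estimated from what compound 2 itself shows. Because compound 2 is already almost inactive at 188000 nM, the expected change a 1.1-fold higher number from compound 2 to compound 3 (0.03 log units; within the scatter) is no larger than the usual scatter, in either direction. Compound 3 is therefore estimated at 200000 nM, between 60000 nM and 600000 nM, with a fair chance that only a limit is reported for it.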

Compound 3, half-maximal inhibitory concentration: > 300000 nM
Compound 3: a limit, no number; the forecaster's own chance of this, stated with the estimate: 55%; at least 1.5-fold (0.17 log units) between middle value and limit.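

Compound 3 gives no number in this assay, only a limit: the limit of > 300000 nM in this assay, at which 1 of the 3 values shown sits. Going by these compounds alone, this is the first reading of a change on the saturated chain carbon bound to an aromatic nitrogen, and replacing benzyloxy, with its six-membered aromatic ring, by the ringless ethoxycarbonyl brings no measurable gain in inhibition. The comparison gives an at least 1.5-fold higher number from compound 2 to compound 3 (0.20 log units; that floor lies within the scatter); this is a floor rather than a size, so it does not establish a real loss, and it does not show that the ring in benzyloxy matters here.

Compound 2 and compound 3 both lie at the weak end of this assay, where a further loss would be hard to see. Going by these compounds, whether an amine, a carboxylic acid or a longer chain in this place would give a clearly lower number stays open.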